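Extending the ethyl chain of a dithiocarbamate lactone

The compounds below may be only part of what the source reports. "The series", "measured", "known", "first", "only" and "open" are said of these compounds alone.

Measured compounds:
- compound 1, `O=C(CSC(=S)N[C@H]1CCOC1=O)Nc1ccccc1Cl`: > 128000 nM
- compound 2, `CC(=O)c1ccc(NC(=O)CSC(=S)N[C@H]2CCOC2=O)cc1`: > 128000 nM
- compound 3, `CCSC(=S)N[C@H]1CCOC1=O`: > 128000 nM

All three compounds were tested in a functional assay on EC9706 cells (Homo sapiens) for cytotoxicity, read by MTT assay, with a stated time of 72 h; on this read-out higher numbers stand for weaker inhibition and lower numbers for stronger inhibition. For compound 1 the result is a limit of the assay, not a number. For compound 2 the result is likewise only a limit. Compound 3 also gives only a limit, so no true number exists for any of them, and nothing can be said about order among them; the shared feature is the limit of > 128000 nM in this assay, at which 3 of the 3 values shown sit. Among the measured compounds shown here, no step between measured compounds that differ in one place can be drawn from these data.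

Compound 4, `CCCCCCCCSC(=S)N[C@H]1CCOC1=O`, has not yet been measured. It differs from compound 3 by hexyl in place of hydrogen on a saturated chain carbon, two bonds along the chain from a sulfur. Since compound 3 gives only a limit in this assay, the step from compound 3 to compound 4 can only be expected as a change toward a measurable value or none beyond the scatter; the expected step is an at least 1.2-fold lower number from compound 3 to compound 4 (0.10 log units; that floor lies within the scatter). The estimate for compound 4 in this assay is 100000 nM, expected to fall between 30000 nM and 300000 nM, with a substantial chance that again only a limit is reported.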

Compound 4, half-maximal inhibitory concentration: > 128000 nM
Compound 4 ended at the assay's limit; the forecaster's own chance of this, stated with the estimate: 65%; at least 1.2-fold (0.10 log units) between middle value and limit.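

As far as these compounds go, no step can be read from compound 3 to compound 4, since neither gives a true number and both results are only limits of the assay, so the effect of the added hexyl stays unknown. What they share is this: the limit of > 128000 nM in this assay, at which 4 of the 4 values shown sit.

The compounds shown leave open whether any change to this shared core gives a measurable value in these cells.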